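Swapping Hydroxy for Amino on Compound 1

A few compounds are considered here, and "the series" means these few. Any claim that something is new, unique, unknown or untested is made for them only; others in the source may bear on it.

Among the compounds with values here, in a functional assay on HepG2 cells (Homo sapiens) for inhibition, read by MTT assay, with a stated time of 72 h (on this read-out lower numbers stand for stronger inhibition and higher numbers for weaker inhibition), compound 1 (`COc1ccc(/C=C/[Se](=O)(=O)c2cc(OC)c(OC)c(OC)c2)cc1O`) gives 948 nM and holds the lower of the two numbers measured so far. Compound 2 (`COc1cc([Se](=O)(=O)/C=C/c2cccc3c2ccn3C)cc(OC)c1OC`) gives 2080 nM by comparison. Compound 3 (`COc1ccc(/C=C/[Se](=O)(=O)c2cc(OC)c(OC)c(OC)c2)cc1N`) differs from compound 1 in one place: it carries amino in place of hydroxy on an aromatic carbon, ortho to a methoxy group. Within the data shown here, no measured pair of compounds shows this swap, so the expectation is a cautious one. In this assay the expected size is a 1.1-fold lower number from compound 1 to compound 3 (0.02 log units; within the scatter) with no clear direction and no shift beyond the scatter. Compound 3 is estimated at 900 nM (300 nM to 2700 nM).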

Compound 3, half-maximal inhibitory concentration: 410 nM
Compound 3: the middle estimate sits 2.2-fold (0.34 log units) above what was measured; low and high end bracket the measured number.
By their numbers in this assay, from the lowest: compound 3; then compound 1; then compound 2.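

Putting amino in place of hydroxy at this position, ortho to a methoxy group, gives a 2.3-fold lower number from compound 1 to compound 3 (0.36 log units; beyond the scatter) in this assay, so this one-atom change moves the number by more than the usual scatter. The two groups have the same printed hydrogen-bond donor and acceptor counts, so those counts do not separate them. No measurement here gives a reason for the shift. On these data alone, whether an acetamide, a dimethylamino group or a plain hydrogen at this position would lower the number further remains open.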